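This account rests on a few compounds, and the source may have more. Where it says the series, first, only, none or still open, it means among the compounds named here.

Compound 1 `c1cncc(CNCCCCN(C[C@H]2Cc3ccccc3CN2)[C@H]2CCCc3cccnc32)c1`: 15.3 nM
Compound 2 `c1ccc2c(c1)CN[C@@H](CN(CCCCNCC1CCSCC1)[C@H]1CCCc3cccnc31)C2`: 69.6 nM

In a functional assay on cells for antagonist activity at C-X-C chemokine receptor type 4 (Homo sapiens), read by fluorescence and calcium flux, with stated times of 25 min and 90 s (a higher number here means a weaker inhibitor, a lower number a stronger inhibitor), compound 1 gives 15.3 nM, while compound 2 gives 69.6 nM. Among the compounds with values here, compound 2 therefore stands with the higher of the two numbers, and its only neighbour is compound 1; the step of a 4.5-fold higher number from compound 1 to compound 2 (0.66 log units; beyond the scatter) lies beyond the scatter. Compound 3 `c1ccc2c(c1)CN[C@@H](CN(CCCCNC1CCSCC1)[C@H]1CCCc3cccnc31)C2` differs from compound 2 by thian-4-yl in place of (thian-4-yl)methyl on an amine nitrogen. Within the data shown here, no measured step removes a chain carbon in this manner. Among the measured compounds shown here, the one step that has been measured, a 4.5-fold higher number from compound 1 to compound 2 (0.66 log units; beyond the scatter), exchanges the ring itself and was modest in size; it does not speak directly to the shortening in hand. With the thian-4-yl ring kept and only the linking carbon lost, the step of a 1.1-fold higher number from compound 2 to compound 3 (0.03 log units; within the scatter) is expected to be small and without a clear direction. Compound 3 is estimated at 75 nM, within a range from 30 nM to 190 nM.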

Compound 3, half-maximal inhibitory concentration: 54.7 nM
Compound 3: the middle estimate sits 1.4-fold (0.14 log units) above what was measured; the range from low to high includes it.
By their numbers in this assay, from the lowest: compound 1; then compounds 3 and 2 (each within the scatter of the next).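

In this assay, the (thian-4-yl)methyl group on the amine nitrogen can lose its linking carbon with only a 1.3-fold lower number from compound 2 to compound 3 (0.10 log units; within the scatter), so for this pair the length of the link has no effect that can be told from scatter. The (pyridin-3-yl)methyl group of compound 1 still keeps its edge, with a 3.6-fold higher number from compound 1 to compound 3 (0.55 log units; beyond the scatter), and so shortening the link does not close the distance to compound 1. No measurement at hand bears on the reason for either step.

On these data alone, it stays open whether a pyridin-3-yl ring set directly on that amine nitrogen would hold the number of compound 1. As far as these compounds go, the outcome of a longer chain, such as a (thian-4-yl)ethyl group, and of a piperidin-4-yl ring in place of thian-4-yl also remains unknown.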